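A few compounds are considered here, and "the series" means these few. Any claim that something is new, unique, unknown or untested is made for them only; others in the source may bear on it.

Measured compounds:
Compound 1 `C=CCn1c(=O)/c(=C\c2cccc(F)c2)[nH]c(=O)/c1=C\c1ccccc1OC`: 6500 nM
Compound 2 `C=CCn1c(=O)/c(=C\c2cc(F)ccc2C)[nH]c(=O)/c1=C\c1ccccc1OC`: 3800 nM

In a functional assay on MOLT-4 cells (Homo sapiens) for cytotoxicity, read by CCK-8 assay, with a stated time of 72 h (on this read-out higher numbers stand for weaker inhibition and lower numbers for stronger inhibition), compound 1 gives 6500 nM, the highest of the two numbers; compound 2 gives 3800 nM, and the step of a 1.7-fold lower number from compound 1 to compound 2 (0.23 log units; within the scatter) lies within the scatter, so the two cannot be ranked. The unmeasured compound 3 `C=CCn1c(=O)/c(=C\c2cccc(C)c2)[nH]c(=O)/c1=C\c1ccccc1OC` differs from compound 1 by methyl in place of fluoro on an aromatic carbon. Within the data shown here, no measured step swaps these two groups; the only step available, a 1.7-fold lower number from compound 1 to compound 2 (0.23 log units; within the scatter), adds a methyl on a different ring and stays within the scatter. Among the measured compounds shown here, with a single small step as the only guide, the expectation for compound 3 is a number close to that of compound 1, with no shift beyond the scatter in either direction, and the step of a 1.2-fold lower number from compound 1 to compound 3 (0.07 log units; within the scatter) is expected to be small. Compound 3 is therefore estimated at 5500 nM, with a range from 2500 nM to 12000 nM.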

Compound 3, half-maximal inhibitory concentration: 16000 nM
Compound 3: middle estimate off by 2.9-fold (0.46 log units), on the low side; measured number outside the range, above it.
By their numbers in this assay, from the lowest: compounds 2 and 1 (each within the scatter of the next); then compound 3.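

In this assay, among these compounds, methyl in place of fluoro at this position, on an aromatic carbon meta to a large group, gives the first change that clearly exceeds the scatter, with a 2.5-fold higher number from compound 1 to compound 3 (0.39 log units; beyond the scatter) in this series. The 3-fluorophenyl and 3-methylphenyl groups are therefore not interchangeable here, even though the swap replaces one heavy atom with one heavy atom, and the gap widens to a 4.2-fold higher number from compound 2 to compound 3 (0.62 log units; beyond the scatter) when the full ring change is read. No measurement shown here accounts for this difference.

The compounds shown leave open whether fluoro helps or methyl hurts, since neither can be compared with a plain hydrogen at this position. On these data alone, it also remains unknown how a chloro group, an amine or a carboxylic acid would behave there.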